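Swapping methoxycarbonyl for 2-methylprop-1-en-1-yl on compound 2

A few compounds are considered here, and "the series" means these few. Any claim that something is new, unique, unknown or untested is made for them only; others in the source may bear on it.

Measured so far in a physicochemical assay for lipophilicity, read by HPLC, using the shake flask method, measured as octanol-water partition, with a stated time of 24 h, at pH 7.4; on this read-out higher numbers stand for higher lipophilicity and lower numbers for lower lipophilicity:
compound 1 (`COC(=O)Cn1c(=O)oc2c(C(=O)/C=C/c3cc(F)c(O)c(F)c3)cccc21`): 1.07
compound 2 (`COC(=O)Cn1c(=O)oc2c(C(=O)/C=C/c3ccc(O)c(O)c3)cccc21`): 0.86

Compound 2 stands level with compound 1 within the scatter (a number 0.21 log units lower from compound 1 to compound 2 (within the scatter)). Compound 3 (`CC(C)=CCn1c(=O)oc2c(C(=O)/C=C/c3ccc(O)c(O)c3)cccc21`) departs from compound 2 at one place (2-methylprop-1-en-1-yl in place of methoxycarbonyl on a saturated chain carbon bound to an aromatic nitrogen), with 2-methylprop-1-en-1-yl in place of methoxycarbonyl on a saturated chain carbon bound to an aromatic nitrogen. Among the compounds with values here, the only measured step (a number 0.21 log units lower from compound 1 to compound 2 (within the scatter)) lies elsewhere on the molecule, so it offers no direct guide to size. Starting from compound 2 (0.86), an all-carbon group with no hydrogen-bond acceptors enters, and a higher number is expected, beyond the scatter. The expected step in this assay is (a number 1.34 log units higher from compound 2 to compound 3 (beyond the scatter)). The estimate for compound 3 is 2.2 (range 1.6 to 2.8).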

Compound 3, distribution coefficient: 0.98
Estimate against measurement, compound 3: 1.22 log units above; measured number below the stated range.
By their numbers in this assay, from the lowest: compounds 2, 3 and 1 (each within the scatter of the next).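

In this assay the change at this position reads as a number 0.12 log units higher from compound 2 to compound 3 (within the scatter) and so stays level, even though the hydrogen-bond acceptors of methoxycarbonyl are absent from the all-carbon 2-methylprop-1-en-1-yl that enters. Within the data shown here, this is the first reading at the saturated chain carbon bound to an aromatic nitrogen, since the earlier step lay elsewhere on the molecule. Nothing available accounts for this result.

As far as these compounds go, whether a carboxylic acid, an amine or a longer chain at this place would also stay within the scatter remains open. So does whether the same swap would read alike on compound 1.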